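The source may report more compounds than this note shows. Statements on the series, on what has been measured and on what is new or still open speak of the compounds shown alone.

Within the data shown here, compound 1 `CC(C)C[C@H](N)c1cc(C(F)(F)F)ccc1N1CCN(C(=O)CSc2ccc(Cl)cc2Cl)CC1` is one of two compounds measured in an assay on HEK293 cells for displacement of a labelled ligand from Melanocortin receptor 4 (Homo sapiens); a higher number here means a weaker inhibitor, a lower number a stronger inhibitor. There compound 1 gives 1500 nM, the highest of the two numbers shown. Compound 2 `Cc1ccc(N2CCN(C(=O)[C@H](C)Cc3ccc(Cl)cc3F)CC2)c([C@@H](N)CC(C)C)c1` stands at the other end: in this assay compound 2 gives 20 nM, a gap well beyond the scatter, and compound 1 is therefore the weaker of the pair. Compound 3 `CC(C)C[C@H](N)c1cc(C(F)(F)F)ccc1N1CCN(C(=O)CCC(=O)N(C)C)CC1` has not yet been measured. It differs from compound 1 in one place: (dimethylcarbamoyl)methyl in place of (2,4-dichlorophenyl)sulfanyl on a saturated chain carbon bound to a carbonyl carbon. Among the measured compounds shown here, no step between measured compounds covers this change, and compound 2 is not a neighbour of compound 1 by a single change, so its value shows only how far apart the two sit. For the measured compounds named here, compound 2 keeps an aromatic ring on the acyl side, and compound 3 gives up the only one compound 1 had there. The step from compound 1 to compound 3 is expected to be a 3.0-fold higher number from compound 1 to compound 3 (0.48 log units; beyond the scatter), towards a higher number. Compound 3 is estimated at 4500 nM, within 900 nM to 20000 nM.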

Compound 3, inhibition constant: > 10000 nM
Compound 3 gave a limit, no number (the forecaster's own chance of this, stated with the estimate: 25%); middle value at least 2.2-fold (0.34 log units) away from the limit.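

In this assay compound 3 reads > 10000 nM, which is a limit of the assay and not a number. This is the first change shown at this place, a saturated chain carbon bound to a carbonyl carbon, and putting (dimethylcarbamoyl)methyl in place of (2,4-dichlorophenyl)sulfanyl gives an at least 6.6-fold higher number from compound 1 to compound 3 (0.82 log units; beyond the scatter), so even from the weak starting point of compound 1 the binding read-out still depends on what sits here. The true size of this step stays unknown, as only its lower end can be read from the limit: the limit of > 10000 nM in this assay, at which 1 of the 3 values shown sits.

The exchange removes the aromatic ring, the sulfur and both chlorines together, so the compounds shown cannot say which of these counts. Going by these compounds, how a plain phenylsulfanyl group, a benzyl group or a carboxylic acid would read at this place remains open.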